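Removing the methoxy group from compound 3

This account rests on a few compounds, and the source may have more. Where it says the series, first, only, none or still open, it means among the compounds named here.

Of the compounds shown here, three that share one core have been measured in a functional assay on EKVX cells (Homo sapiens) for inhibition, read by sulforhodamine B assay, with a stated time of 48 h; a lower number here means a stronger inhibitor of growth, a higher number a weaker inhibitor of growth. Compound 1 `N#C/C(=C\c1c(-c2ccccc2)[nH]c2ccccc12)C(=O)c1ccccc1` gives 10000 nM in this assay. Compound 2 `CC(=O)/C(=C\c1c(-c2ccccc2)[nH]c2ccccc12)S(=O)(=O)c1ccccc1` gives 3300 nM in this assay. Compound 3 `COc1ccc(-c2[nH]c3ccccc3c2/C=C(\C#N)S(=O)(=O)c2ccccc2)cc1` gives 1300 nM in this assay, the lowest of the three numbers. Its nearest neighbour is compound 2, whose number is higher by an amount beyond the usual scatter, and compound 1 stands furthest away with a still higher number. Compound 3 is therefore the strongest inhibitor of growth among the three.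

The question now concerns compound 4 `N#C/C(=C\c1c(-c2ccccc2)[nH]c2ccccc12)S(=O)(=O)c1ccccc1`, which has not been measured. It differs from compound 3 in one place: hydrogen in place of methoxy on an aromatic carbon. Going by the values given here, no pair of measured compounds shows this particular change in this assay, so the size of the step has to be judged without a direct precedent. Among the compounds with values here, compound 3, the only compound carrying the methoxy group, also gives the lowest number, and the methoxy group is what compound 4 lacks. A moderate rise in the number is therefore expected, though the remaining compounds do not settle the point, and the step from compound 3 to compound 4 is estimated at a 2.3-fold higher number from compound 3 to compound 4 (0.36 log units; beyond the scatter). Compound 4 is expected to give 3000 nM in this assay, within a range from 1000 nM to 9000 nM.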

Compound 4, concentration for 50% growth inhibition: 6200 nM
The estimate for compound 4 lay 2.1-fold (0.32 log units) below the measured number; the range from low to high includes it.
By their numbers in this assay, from the lowest: compound 3; then compounds 2, 4 and 1 (each within the scatter of the next, the first and the last beyond it).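

In this assay, going by these compounds alone, the change from 4-methoxyphenyl to phenyl gives a 4.8-fold higher number from compound 3 to compound 4 (0.68 log units; beyond the scatter), the first step that can be read at this position. In this pair, the methoxy group on an aromatic carbon, para to a large group, goes with the stronger inhibition of growth. The two changes on the double-bonded chain carbon stay within the scatter: cyano in place of acetyl gives a 1.9-fold higher number from compound 2 to compound 4 (0.27 log units; within the scatter), and phenylsulfonyl in place of benzoyl gives a 1.6-fold lower number from compound 1 to compound 4 (0.21 log units; within the scatter), so of the three single changes now readable, only the loss of the methoxy group moves the number beyond the scatter.

No measurement at hand speaks to the reason for this step. Going by these compounds, whether a hydroxyl group, an amine or a longer chain such as ethoxy in the same place would give a number closer to that of compound 3 or to that of compound 4 stays open, as does whether the methoxy step would hold with acetyl or benzoyl on the chain.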